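From phenyl to cyclopropylmethyl on a sulfonamide nitrogen

The source may hold more compounds than are shown below. What is called first, only, known or untested is meant among the compounds shown, and "the series" means these compounds.

In an ADME assay (liver) for metabolic stability, with Liver microsome (Rattus norvegicus) as the target, using microsomes and NADPH, with a stated time of 30 min (a lower number here means slower removal, a higher number faster removal of the compound), compound 1 `CC#C[C@H]1CN(S(=O)(=O)c2ccc(N)nc2)CCN1c1ccc(S(=O)(=NC)C(F)(F)F)cc1` gives 257 mL.min-1.g-1.

Compound 2 `CC#C[C@H]1CN(S(=O)(=O)c2ccc(N)nc2)CCN1c1ccc(S(=O)(=O)Nc2ccccc2)cc1` gives > 399 mL.min-1.g-1 in this assay, which is a limit of the assay and not a number.

Compound 3 `CC#C[C@H]1CN(S(=O)(=O)c2ccc(N)nc2)CCN1c1ccc(S(=O)(=O)NCC2CC2)cc1` has not yet been measured. It differs from compound 2 as follows: cyclopropylmethyl in place of phenyl on a sulfonamide nitrogen.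

Among the measured compounds shown here, the one measured step that bears on this is an at least 1.5-fold higher number from compound 1 to compound 2 (0.19 log units; that floor lies within the scatter). That step exchanged a whole group on an aromatic carbon and gives only a floor, so it offers weak guidance on size.

For the measured compounds named here, with compound 1 at 257 mL.min-1.g-1 as the only true number available, compound 3 is expected to land in that region. A limit reading is still possible for compound 3. The estimated change is an at least 1.3-fold lower number from compound 2 to compound 3 (0.12 log units; that floor lies within the scatter).

For compound 3 the estimated value is 300 mL.min-1.g-1, within an expected range from 140 mL.min-1.g-1 to 600 mL.min-1.g-1.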

Compound 3, intrinsic clearance in microsomes: 213 mL.min-1.g-1
Estimate against measurement, compound 3: 1.4-fold (0.15 log units) above; the measured number falls inside the stated range.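

On the sulfonamide nitrogen, cyclopropylmethyl in place of phenyl gives an at least 1.8-fold lower number from compound 2 to compound 3 (0.27 log units; that floor lies within the scatter) in this assay. This step can be read only as a floor and the real difference may be larger, because compound 2 sits at a limit of the assay and not at a number: the limit of > 399 mL.min-1.g-1 in this assay, at which 1 of the 3 values shown sits. Exchanging the whole group on the aromatic carbon gives a 1.2-fold lower number from compound 1 to compound 3 (0.08 log units; within the scatter), so the two groups cannot be told apart in this assay.

From the compounds shown here alone, how far the reading for phenyl really lies from the one for cyclopropylmethyl remains open. So does the outcome with other groups on the sulfonamide nitrogen, such as a plain methyl, a longer chain or a chain ending in an amine.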